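From 3,5-dichlorophenyl to 2-iodophenyl on the shared core

This account rests on a few compounds, and the source may have more. Where it says the series, first, only, none or still open, it means among the compounds named here.

Among the compounds with values here, three aryl variants of one core have numbers so far. Compound 1 `COC(=O)C1=C(C)N=C(C)/C(=C(\O)OC)C1c1cc(Cl)cc(Cl)c1` gives 93.3 nM in a functional assay (muscle tissue) with Cavia porcellus as the target (a higher number here means that more compound is needed for the effect, a lower number that less compound is needed), and holds the middle place of the three. Compound 2 `COC(=O)C1=C(C)N=C(C)/C(=C(\O)OC)C1c1c(F)c(F)c(F)c(F)c1F` carries fluorine on its aromatic ring and gives 4.37 nM as the lowest number. Compound 3 `COC(=O)C1=C(C)N=C(C)/C(=C(\O)OC)C1c1cc(OC)c(OC)cc1OC` carries methoxy groups on that ring and gives 1000000 nM as the highest number. Both gaps around compound 1 lie beyond the scatter.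

Compound 4 `COC(=O)C1=C(C)N=C(C)/C(=C(\O)OC)C1c1ccccc1I` keeps the core of compound 1 and has 2-iodophenyl in place of 3,5-dichlorophenyl on a saturated ring carbon next to the ring atom that bears a methoxycarbonyl group. Within the data shown here, no measured compound carries iodine, and no measured pair differs in one place, so the expectation rests on a thin base. The two halogen-bearing compounds, compound 1 at 93.3 nM and compound 2 at 4.37 nM, set the likely region, far from compound 3 at 1000000 nM in this assay terms.

The expected step is a 6.2-fold lower number from compound 1 to compound 4 (0.79 log units; beyond the scatter) towards a lower number, probably beyond the scatter, though no change remains possible. Compound 4 is estimated at 15 nM with an expected range from 2 nM to 100 nM in this series.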

Compound 4, half-maximal effective concentration: 46.8 nM
For compound 4 the middle estimate is 3.1-fold (0.49 log units) below the measured one, within the range that was stated.
By their numbers in this assay, from the lowest: compound 2; then compounds 4 and 1 (each within the scatter of the next); then compound 3.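

At this position, a saturated ring carbon next to the ring atom that bears a methoxycarbonyl group, the series now has its first comparison of compounds that differ in one place. In this assay the exchange of 3,5-dichlorophenyl for 2-iodophenyl gives a 2.0-fold lower number from compound 1 to compound 4 (0.30 log units; within the scatter) and so leaves the two compounds indistinguishable; at this position, the aromatic ring with one iodine and the aromatic ring with two chlorines read alike in this functional read-out, on this single pair. No measured data on hand speak to why these two groups read alike.

Within the data shown here, the step exchanges both the kind of halogen and the number and placing of the halogens on the aromatic ring at once, so the single pair cannot separate these contributions, and 2-chlorophenyl, 3-iodophenyl and unsubstituted phenyl on the shared core would be needed to pull them apart. Also open is how this assay responds at this position to an aromatic ring carrying an amine or a carboxylic acid, groups that lie outside the halogen and methoxy substituents shown so far.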